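Swapping the aryl group on the shared core: toward compound 4

A few compounds are considered here, and "the series" means these few. Any claim that something is new, unique, unknown or untested is made for them only; others in the source may bear on it.

Compound 1 `COc1cc(-c2ccnc3cc(-c4ccc(F)cc4)nn23)cc(OC)c1OC`: 4540 nM
Compound 2 `COc1cc(-c2ccnc3cc(-c4cccc(C#N)c4)nn23)cc(OC)c1OC`: > 10000 nM
Compound 3 `COc1cc(-c2ccnc3cc(-c4ccc5cc[nH]c5c4)nn23)cc(OC)c1OC`: 55 nM

Of the compounds shown here, three with a common core have been measured in a functional assay on B16-F0 cells (Mus musculus) for inhibition, read by CCK-8 assay, with a stated time of 48 h; on this read-out higher numbers stand for weaker inhibition and lower numbers for stronger inhibition. Compound 1 gives 4540 nM. Compound 3 gives 55 nM, a large step from compound 1, an 83-fold lower number from compound 1 to compound 3 (1.92 log units; beyond the scatter). For compound 2 only a limit is available in this assay: it sits at the limit of > 10000 nM in this assay, at which 1 of the 3 values shown sits. The step of an at least 2.2-fold higher number from compound 1 to compound 2 (0.34 log units; beyond the scatter) is therefore at least modest, and an at least 180-fold lower number from compound 2 to compound 3 (2.25 log units; beyond the scatter) is large.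

Compound 4 `COc1cc(-c2ccnc3cc(-c4ccc(C(C)(C)C)cc4)nn23)cc(OC)c1OC` has not been measured. It differs from compound 2 by 4-(tert-butyl)phenyl in place of 3-cyanophenyl on an aromatic carbon. Within the data shown here, no measured pair carries the 4-(tert-butyl)phenyl group, so the step from compound 2 to compound 4 can only be framed by its neighbours: the 3-cyanophenyl of compound 2 gave a weaker result than the 4-fluorophenyl of compound 1, while the 1H-indol-6-yl of compound 3 gave a far stronger one. A six-membered carbon ring with a para substituent, as in compound 1, is the closer comparison. Compound 4 is therefore expected to land near compound 1, which would mean an at least 1.6-fold lower number from compound 2 to compound 4 (0.22 log units; that floor lies within the scatter) as an estimated step. The estimate for compound 4 is 6000 nM, with a range from 1500 nM to 20000 nM.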

Compound 4, half-maximal inhibitory concentration: > 10000 nM
Compound 4: only a limit was reported; the forecaster's own chance of this, stated with the estimate: 35%; middle value at least 1.6-fold (0.22 log units) away from the limit.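

In this assay compound 4 reads only as a limit, not a number, and it now shares that limit with compound 2, so the step between those two cannot be read: the limit of > 10000 nM in this assay, at which 2 of the 4 values shown sit.

Against the other two compounds the change can be read: tert-butyl in place of fluoro gives an at least 2.2-fold higher number from compound 1 to compound 4 (0.34 log units; beyond the scatter), and 4-(tert-butyl)phenyl in place of 1H-indol-6-yl gives an at least 180-fold higher number from compound 3 to compound 4 (2.25 log units; beyond the scatter). The earlier compounds had shown one substituted phenyl group falling short of the 4-fluorophenyl of compound 1, and compound 4 shows that this also happens with a different group at a different ring position, so on this aromatic carbon the three substituted phenyl groups shown all stay far from the 1H-indol-6-yl of compound 3.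

The compounds shown leave open which part of the 1H-indol-6-yl group carries the large gain, and whether a 1H-indol-5-yl, a 2-naphthyl or a 4-aminophenyl group on the same carbon would keep it. They also leave open how far compound 2 and compound 4 actually lie beyond the limit they share.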